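A few compounds are considered here, and "the series" means these few. Any claim that something is new, unique, unknown or untested is made for them only; others in the source may bear on it.

Measured so far:
- compound 1, `O=C(NCc1cccc(C(F)(F)F)c1)c1cnn(-c2ccc(Cl)cc2)c1C(F)(F)F`: > 3000 nM
- compound 2, `O=C(NCc1cccc(C(F)(F)F)c1)c1cnn(-c2ccc(Cl)cc2)c1CO`: 1200 nM

Both were tested in a functional assay on cells for antagonist activity at C-C chemokine receptor type 1 (Homo sapiens), read by FLIPR and calcium flux; on this read-out lower numbers stand for stronger inhibition and higher numbers for weaker inhibition. For compound 1 the result is only a limit of the assay, > 3000 nM, not a number. Compound 2 gives 1200 nM in this assay, and it is the only number shown. The other result, that of compound 1, sits at a limit (the limit of > 3000 nM in this assay, at which 1 of the 2 values shown sits). Among the measured compounds shown here, the single measured step is an at least 2.5-fold lower number from compound 1 to compound 2 (0.39 log units; beyond the scatter).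

Compound 3, `Nc1c(C(=O)NCc2cccc(C(F)(F)F)c2)cnn1-c1ccc(Cl)cc1`, has not yet been tested. It differs from compound 2 in one place: amino in place of hydroxymethyl on an aromatic carbon. For the measured compounds named here, the only measured step that bears on this position is the one from compound 1 to compound 2, where hydroxymethyl replaced trifluoromethyl. Going by the values given here, no measured step involves an amino group, so the evidence is thin; the counted difference shows one hydrogen-bond donor and one acceptor leaving and one of each entering. The step from compound 2 to compound 3 is therefore expected to stay within the scatter or to move only slightly, a 1.3-fold lower number from compound 2 to compound 3 (0.12 log units; within the scatter). For compound 3 in this assay the estimate is 900 nM, with a range from 300 nM to 3000 nM.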

Compound 3, half-maximal inhibitory concentration: > 3000 nM
Compound 3: a limit, no number (the forecaster's own chance of this, stated with the estimate: 20%); middle value at least 3.3-fold (0.52 log units) away from the limit.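

In this assay, amino in place of hydroxymethyl on this aromatic carbon gives an at least 2.5-fold higher number from compound 2 to compound 3 (0.39 log units; beyond the scatter), so the position responds to a swap between two small groups and not only to the loss of trifluoromethyl. Amino and hydroxymethyl are counted as having the same hydrogen-bond donors and acceptors, so that count alone does not settle the result here, and of the three groups tried at this position only hydroxymethyl gives a number. The result for compound 3 is a limit of the assay and not a number, and the step between compound 1 and compound 3 cannot be read, because both results are limits: the limit of > 3000 nM in this assay, at which 2 of the 3 values shown sit.

Going by these compounds, what remains open is which part of hydroxymethyl matters, its oxygen or its carbon, and a plain methyl, a methoxymethyl or a longer chain such as hydroxyethyl at this position would help separate the two. A carboxylic acid or a primary amide here would show whether a different oxygen-bearing group can bring the number lower than that of compound 2, 1200 nM.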